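Five-membered azoles on the shared core: compound 4

The compounds below may be only part of what the source reports. "The series", "measured", "known", "first", "only" and "open" are said of these compounds alone.

Compound 1 `O=C(O)c1cc(-c2cc[nH]n2)ccc1O` carries a 1H-pyrazol-3-yl group on the shared core. In a functional assay on the whole organism for inhibition, with Rattus norvegicus as the target, read by paw edema (a higher number here means that more compound is needed for the effect, a lower number that less compound is needed), compound 1 gives > 250 mg/kg, which is a limit of the assay and not a number (the limit of > 250 mg/kg in this assay, at which 1 of the 3 values shown sits). Compound 1 thus has no measured dose of its own within the series. Among the measured compounds shown here, compound 2 `O=C(O)c1ccc(-c2cscn2)cc1O` is the one member with a measured dose, giving 70 mg/kg in this assay. Compound 3 `O=C(O)c1cc(-c2ccncn2)ccc1O` gives > 200 mg/kg in this assay, again a limit (the limit of > 200 mg/kg in this assay, at which 1 of the 3 values shown sits). Compound 4 `O=C(O)c1cc(-n2ccnn2)ccc1O` is not yet measured; it differs from compound 1 by 1H-1,2,3-triazol-1-yl in place of 1H-pyrazol-3-yl on an aromatic carbon, in words 1H-1,2,3-triazol-1-yl in place of 1H-pyrazol-3-yl on an aromatic carbon. For the measured compounds named here, no pair of measured compounds differing in one place exists in this set, so the size of such a change cannot be read from the data. Two of the three values shown sit at a limit, and compound 1 itself is a limit, so the expectation for compound 4 is a further limit rather than a measured dose, the expected step being a number no higher from compound 1 to compound 4 (the limit leaves the size open), none beyond the scatter. Compound 4 is estimated at 250 mg/kg, between 60 mg/kg and 1000 mg/kg.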

Compound 4, dose for half-maximal effect: 150 mg/kg
Beside the measured number, compound 4's estimate is 1.7-fold (0.22 log units) above it; the range from low to high includes it.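

At the place para to a hydroxy group and meta to a carboxy group, compound 4 gives 150 mg/kg in this assay, the only measured dose for a group at this place among the compounds shown. Putting 1H-1,2,3-triazol-1-yl in place of 1H-pyrazol-3-yl gives an at least 1.6-fold lower number from compound 1 to compound 4 (0.22 log units; that floor lies within the scatter). The value of compound 1 is a limit and not a number, so this step is only a floor: the limit of > 250 mg/kg in this assay, at which 1 of the 4 values shown sits.

The two groups differ both in their hydrogen-bond donor and acceptor counts and in attachment through ring nitrogen rather than ring carbon, and a single step cannot separate these differences. On these data alone, how a 1H-imidazol-1-yl group or a simple amine at this place would read in this assay remains open.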